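Piperidine in Place of Piperazine on the Shared Core

This account rests on a few compounds, and the source may have more. Where it says the series, first, only, none or still open, it means among the compounds named here.

Compound 1 `O=C1NC(=O)c2c1c1c3ccc(CN4CCC4)cc3[nH]c1c1c2c2cccc3c2n1CCC3`: in a functional assay on HCT-116 cells (Homo sapiens) for cytotoxicity (on this read-out lower numbers stand for stronger inhibition and higher numbers for weaker inhibition), compound 1 gives 230 nM.
Compound 2 `O=C1NC(=O)c2c1c1c3ccc(CN4CCNCC4)cc3[nH]c1c1c2c2cccc3c2n1CCC3`: in this assay compound 2 reaches only the limit of the assay, > 10000 nM.
Compound 3 `O=C1NC(=O)c2c1c1c3ccc(CN4CCCNCC4)cc3[nH]c1c1c2c2cccc3c2n1CCC3`: in this assay compound 3 gives 7600 nM.

Compound 2 thus stands at the limit of this assay and no number is known for it; (the limit of > 10000 nM in this assay, at which 1 of the 3 values shown sits). Compound 4 `O=C1NC(=O)c2c1c1c3ccc(CN4CCCCC4)cc3[nH]c1c1c2c2cccc3c2n1CCC3` has not yet been measured. It differs from compound 2 in one place: piperidin-1-yl in place of piperazin-1-yl on a saturated chain carbon bound to an aromatic carbon.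

Within the data shown here, two measured steps bear on this change, as both alter the same ring on the saturated chain carbon bound to an aromatic carbon. The step of an at least 43-fold higher number from compound 1 to compound 2 (1.63 log units; beyond the scatter) and the step of a 33-fold higher number from compound 1 to compound 3 (1.52 log units; beyond the scatter) show that exchanging azetidin-1-yl for a ring bearing a second nitrogen raised the number strongly. Piperidin-1-yl, like azetidin-1-yl, carries a single nitrogen, so the move from compound 2 toward compound 4 is expected to run the other way, by a large step.

Compound 4 is therefore expected to give 400 nM in this assay, between 100 nM and 3000 nM, which would mean an estimated step of an at least 25-fold lower number from compound 2 to compound 4 (1.39 log units; beyond the scatter).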

Compound 4, half-maximal inhibitory concentration: 320 nM
Compound 4: middle estimate off by 1.3-fold (0.10 log units), on the high side; measured number inside the range.
By their numbers in this assay, from the lowest: compounds 1 and 4 (each within the scatter of the next); then compound 3. At a limit, above all of these: compound 2.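

In this assay, among these compounds, piperidin-1-yl in place of piperazin-1-yl gives an at least 31-fold lower number from compound 2 to compound 4 (1.49 log units; beyond the scatter); the ring stays six-membered, so this large step comes with the loss of the second ring nitrogen alone, which the earlier compounds could not separate from a change in ring size. Compound 2 has only a limit of the assay and no number, so that step is a floor: the limit of > 10000 nM in this assay, at which 1 of the 4 values shown sits. With 1,4-diazepan-1-yl leaving, the result is a 24-fold lower number from compound 3 to compound 4 (1.38 log units; beyond the scatter), whereas the exchange of the two rings with a single nitrogen gives a 1.4-fold higher number from compound 1 to compound 4 (0.14 log units; within the scatter), so among the four compounds only those with a second ring nitrogen, compound 2 and compound 3, lie at the high end of the read-out, and none goes against this.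

The compounds shown leave open whether the second ring nitrogen matters as a nitrogen or through the hydrogen it carries, which a morpholine ring or a methyl group on that nitrogen would help to separate. They also leave open whether rings with a single nitrogen other than azetidine and piperidine, such as pyrrolidine, would stay at this level.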